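The source may hold more compounds than are shown below. What is called first, only, known or untested is meant among the compounds shown, and "the series" means these compounds.

Working notes on the series. Compound 1 `COC(=O)CN1C(=O)c2ccccc2NC1c1ccccc1` is the reference point. Going by the values given here, in an assay on mitochondria for inhibition of Amine oxidase [flavin-containing] B (Bos taurus), read by fluorescence, with a stated time of 60 min (a higher number here means a weaker inhibitor, a lower number a stronger inhibitor), compound 1 gives 720000 nM, the highest of the three numbers measured so far. Compound 2 `COC(=O)CN1C(=O)c2ccccc2NC1c1ccco1` gives 380000 nM and compound 3 `COC(=O)CN1C(=O)c2ccccc2NC1c1ccc(OC)cc1` gives 560000 nM in this assay. The steps among these three, a 1.9-fold lower number from compound 1 to compound 2 (0.28 log units; within the scatter), a 1.3-fold lower number from compound 1 to compound 3 (0.11 log units; within the scatter) and a 1.5-fold higher number from compound 2 to compound 3 (0.17 log units; within the scatter), all fall within the scatter, so the three aryl variants on the saturated ring carbon are not separated by the data.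

Compound 4 `NNC(=O)CCN1C(=O)c2ccccc2NC1c1ccccc1` has not yet been measured. It differs from compound 1 as follows: (aminocarbamoyl)methyl in place of methoxycarbonyl on a saturated chain carbon bound to an amide-type nitrogen in a ring. Among the compounds with values here, none of the measured steps touches this place; each of them alters the group on the saturated ring carbon, and none alters the chain bound to the amide-type nitrogen in the ring. Within the data shown here, there is therefore no step in hand that bears directly on the change from compound 1 to compound 4, and the only guidance is that every change made so far has left the number inside the scatter. The expectation for compound 4 in this assay is accordingly a step of a 1.0-fold lower number from compound 1 to compound 4 (0.01 log units; within the scatter), that is, none beyond the scatter. Compound 4 is estimated at 700000 nM, with a range from 250000 nM to 2000000 nM.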

Compound 4, half-maximal inhibitory concentration: 210000 nM
Estimate against measurement, compound 4: 3.3-fold (0.52 log units) above; measured number below the stated range.
By their numbers in this assay, from the lowest: compounds 4, 2, 3 and 1 (each within the scatter of the next, the first and the last beyond it).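

Going by these compounds alone, compound 4 gives the first step that lies beyond the scatter in this assay: a 3.4-fold lower number from compound 1 to compound 4 (0.54 log units; beyond the scatter), a modest one. The chain on the amide-type nitrogen in the ring is therefore a place where a change does move the number, which the group on the saturated ring carbon, varied among compounds 1, 2 and 3, did not show; here the entering (aminocarbamoyl)methyl carries 2 hydrogen-bond donors where the leaving methoxycarbonyl carries 0, with 2 hydrogen-bond acceptors on each side. Nothing in hand bears on what lies behind this step.

The same difference, read as (methoxycarbonyl)methyl to 2-(aminocarbamoyl)ethyl, alters the chain length and the end group together, so the compounds shown cannot say which of the two carries the step; a 2-(methoxycarbonyl)ethyl chain, or a carboxylic acid or an amine at the end of the longer chain, would pull them apart. Also open, from the compounds shown here alone, is whether the step holds with furan-2-yl or 4-methoxyphenyl on the saturated ring carbon in place of phenyl.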